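This account rests on a few compounds, and the source may have more. Where it says the series, first, only, none or still open, it means among the compounds named here.

Within the data shown here, compound 2 `COc1cc2nnc(C(N)=O)c(Nc3ccc(C)cc3F)c2cc1N1CCC(N(C)C)CC1` gives 34 mL/min/kg in an ADME assay on the whole organism for pharmacokinetics, with Rattus norvegicus as the target, at a dose of 10 mg/kg by the oral route (on this read-out lower numbers stand for slow clearance and higher numbers for fast clearance), one of only two numbers measured so far. The other comes from compound 1 `COc1cc2nnc(C(N)=O)c(Nc3ccc(C)cc3F)c2cc1N1CCN(C(C)C)CC1`, which gives 17 mL/min/kg in this assay, and the step of a 2.0-fold higher number from compound 1 to compound 2 (0.30 log units; within the scatter) lies within the scatter. Compound 3 `COc1cc2nnc(C(N)=O)c(Nc3ccc(C)cc3F)c2cc1N1CCC(OC)CC1` differs from compound 2 by methoxy in place of dimethylamino on a saturated ring carbon. Among the measured compounds shown here, the only measured step that bears on this change is that one from compound 1 to compound 2, which swapped the whole ring group and still stayed within the scatter, so no step beyond the scatter is expected here. Compound 3 is therefore expected at 30 mL/min/kg, with a range from 15 mL/min/kg to 60 mL/min/kg. That expectation amounts to a step of a 1.1-fold lower number from compound 2 to compound 3 (0.05 log units; within the scatter).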

Compound 3, clearance: 58 mL/min/kg
For compound 3 the middle estimate is 1.9-fold (0.29 log units) below the measured one; the measured number falls inside the stated range.
By their numbers in this assay, from the lowest: compounds 1, 2 and 3 (each within the scatter of the next, the first and the last beyond it).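

In this assay, methoxy in place of dimethylamino on the saturated ring carbon gives a 1.7-fold higher number from compound 2 to compound 3 (0.23 log units; within the scatter) and so stays within the scatter, which means that this ring carbon can carry either group without a clear step. Among these compounds, changing the whole ring group gives a 3.4-fold higher number from compound 1 to compound 3 (0.53 log units; beyond the scatter) and is the first step here beyond the scatter, though a modest one. Nothing shown here explains this step. On these data alone, a hydroxyl group, a primary amine or a longer ether chain such as ethoxy on this ring carbon remains open.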